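The compounds below may be only part of what the source reports. "The series", "measured", "known", "first", "only" and "open" are said of these compounds alone.

Compound 1, `CCCCCCSC[C@H]1C2CCC(O2)[C@H]1C/C=C\CCCC(=O)O`: 3800 nM in a functional assay on a cell-free system (plasma) for inhibition of thromboxane A2 receptor (Homo sapiens); on this read-out higher numbers stand for weaker inhibition and lower numbers for stronger inhibition.
Compound 2, `O=C(O)CCC/C=C\CC1C2CCC(O2)C1CSCCc1ccccc1`: 5500 nM in this assay.

Compound 2 gives the higher of the two numbers, but compound 1 sits within the scatter of it, so the two cannot be ranked. Compound 3, `CCCCSCC1C2CCC(O2)C1C/C=C\CCCC(=O)O`, differs from compound 2 by ethyl in place of phenyl on a saturated chain carbon, two bonds along the chain from a sulfur. Within the data shown here, no step between measured compounds is known here, so the size of this change has to be judged from the structures alone. Compound 1 carries a plain alkyl chain on the sulfur and gives 3800 nM in this assay. The step of a 1.1-fold higher number from compound 2 to compound 3 (0.04 log units; within the scatter) is expected to stay within the scatter, neither clearly up nor down. Compound 3 is expected to give 6000 nM, most likely between 2000 nM and 20000 nM.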

Compound 3, half-maximal inhibitory concentration: 1000 nM
The estimate for compound 3 lay 6.0-fold (0.78 log units) above the measured number; the whole stated range lies above it.
By their numbers in this assay, from the lowest: compound 3; then compounds 1 and 2 (each within the scatter of the next).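

Ethyl in place of phenyl on a saturated chain carbon, two bonds along the chain from a sulfur, gives a 5.5-fold lower number from compound 2 to compound 3 (0.74 log units; beyond the scatter) in this assay and so shows that this position responds to the group it carries. Here, giving up the aromatic ring does not cost inhibition; in this one pair, the ring-free group gives the stronger inhibition. No measurement shown accounts for this step.

Going by these compounds, whether the aromatic ring itself matters or only the size of the group stays open. A cyclohexyl group or an amine in this place could help to tell.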